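Demethylation on two cores in an antiproliferative cell assay

A few compounds are considered here, and "the series" means these few. Any claim that something is new, unique, unknown or untested is made for them only; others in the source may bear on it.

Four compounds are considered here. Compound 1 `COc1cc(OC)c2c(=O)n(Cc3ccccc3)ccc2c1` and compound 2 `COc1cc(O)c2c(=O)n(Cc3ccccc3)ccc2c1` share one core, while compound 3 `COc1cc2c(c(OC)c1)C(=O)N(c1cccc(C(=O)N3CCCCC3)c1)CC2` and compound 4 `COc1cc(O)c2c(c1)CCN(c1cccc(C(=O)N3CCCCC3)c1)C2=O` share another; the difference between the two cores is not broken down here. In a functional assay on A-431 cells (Homo sapiens) for antiproliferative activity, read by MTT assay, with a stated time of 72 h (a higher number here means a weaker inhibitor, a lower number a stronger inhibitor), compound 1 gives 3880 nM, and compound 2 gives 8290 nM. The change between them is hydrogen in place of methyl on an oxygen on an aromatic ring, and it produced a 2.1-fold higher number from compound 1 to compound 2 (0.33 log units; beyond the scatter). Compound 3 gives 10800 nM in this assay; its number is within the scatter of that of compound 2, and it sits beyond the scatter above compound 1.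

Compound 4 has not yet been measured. It differs from compound 3 by hydrogen in place of methyl on an oxygen on an aromatic ring, which is the same change as that from compound 1 to compound 2, made at the same kind of place on the aromatic ring. Among the measured compounds shown here, it is expected that the step from compound 3 to compound 4 in this assay will be of similar size to the earlier one, namely a 2.0-fold higher number from compound 3 to compound 4 (0.31 log units; beyond the scatter), and this rests only on the single measured pair, because a 2.1-fold higher number from compound 1 to compound 2 (0.33 log units; beyond the scatter) is the one example of this change available. On that basis compound 4 is estimated to give 22000 nM in this assay, with a plausible range from 9000 nM to 55000 nM.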

Compound 4, half-maximal inhibitory concentration: 5320 nM
The estimate for compound 4 lay 4.1-fold (0.62 log units) above the measured number; measured number below the stated range.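

In this assay, the change from methoxy to hydroxy gave a 2.0-fold lower number from compound 3 to compound 4 (0.31 log units; beyond the scatter), which runs in the opposite direction to the step measured on the other core. The same change therefore cannot be carried from one core to the other in this series, even in direction, and the two results differ by more than the scatter of two such steps: the same change on two cores in this assay, a 2.1-fold higher number (0.33 log units; beyond the scatter) from compound 1 to compound 2 and a 2.0-fold lower number (0.31 log units; beyond the scatter) from compound 3 to compound 4, 4.3-fold (0.64 log units) apart, beyond the scatter of two such steps. This shows that the effect of the change depends on its surroundings in these four compounds, but it rests on a single pair per core and does not show which structural difference between the cores reverses the step, nor does it give any explanation for the reversal.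

The compounds shown leave open whether the opposite steps follow from the core itself or from the different groups attached to it, since these differences are not separated in any pair here. They also leave open whether a longer chain on the same oxygen, such as ethoxy, or an amine in place of the hydroxy would split between the two cores in the same way.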